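Removing a methoxy group from the bicyclic core

The source may hold more compounds than are shown below. What is called first, only, known or untested is meant among the compounds shown, and "the series" means these compounds.

Measured compounds:
compound 1 `O=C(Nc1ccc(-c2cnc3ccccn23)cc1)c1ccc([N+](=O)[O-])o1` gives 360 nM
compound 2 `COc1ccn2c(-c3ccc(NC(=O)c4ccc([N+](=O)[O-])o4)cc3C)cnc2c1` gives 640 nM

Both compounds were tested in a functional assay on AGS cells (Homo sapiens) for antiproliferative activity, read by CCK-8 assay, with a stated time of 72 h; on this read-out lower numbers stand for stronger inhibition and higher numbers for weaker inhibition. Compound 2 holds the higher of the two numbers, with compound 1 close by, and the gap between them lies within the scatter of repeated measurements. The unmeasured compound 3 `Cc1cc(NC(=O)c2ccc([N+](=O)[O-])o2)ccc1-c1cnc2ccccn12` differs from compound 2 by hydrogen in place of methoxy on an aromatic carbon. For the measured compounds named here, no comparable step between measured compounds exists here. The step is estimated as a 1.4-fold lower number from compound 2 to compound 3 (0.15 log units; within the scatter), a small expected shift toward a somewhat lower number that is not clearly beyond the scatter. Compound 3 is expected at 450 nM, within a range from 200 nM to 1100 nM.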

Compound 3, half-maximal inhibitory concentration: 390 nM
The estimate for compound 3 lay 1.2-fold (0.06 log units) above the measured number; the range from low to high includes it.
By their numbers in this assay, from the lowest: compounds 1, 3 and 2 (each within the scatter of the next).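

In this assay, hydrogen in place of methoxy on the aromatic carbon opposite the ring nitrogen gives a 1.6-fold lower number from compound 2 to compound 3 (0.22 log units; within the scatter) and so leaves the two numbers indistinguishable. Methyl in place of hydrogen on an aromatic carbon gives a 1.1-fold higher number from compound 1 to compound 3 (0.03 log units; within the scatter) and likewise produces no readable difference, so neither group clearly matters in this small set. Nothing available explains either result.

On these data alone, whether an amine or a carboxylic acid at the methoxy position would move the number beyond the scatter stays open. So does the behaviour of methoxy without the methyl.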